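A few compounds are considered here, and "the series" means these few. Any claim that something is new, unique, unknown or untested is made for them only; others in the source may bear on it.

Compound 1 `COc1cc(/C(=C/c2ccc(C)cc2)C(C)O)cc(OC)c1OC` gives 33500 nM in a functional assay on L1210 cells (Mus musculus) for antiproliferative activity, read by MTT assay, with a stated time of 72 h; on this read-out lower numbers stand for stronger inhibition and higher numbers for weaker inhibition. Compound 2 `COc1cc(/C(=C/c2ccc(Cl)cc2)C(C)O)cc(OC)c1OC` gives > 100000 nM, which is a limit of the assay and not a number. Compound 3 `COc1cc(/C(=C/c2ccc(Br)cc2)C(C)O)cc(OC)c1OC` gives > 100000 nM, again a limit. Compound 2 therefore has no exact value and stands at the limit of > 100000 nM in this assay, at which 2 of the 3 values shown sit.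

Compound 4 `COc1cc(/C(=C/c2ccc([N+](=O)[O-])cc2)C(C)O)cc(OC)c1OC` has not yet been measured. It carries nitro in place of chloro on an aromatic carbon, para to a large group: nitro in place of chloro on an aromatic carbon.

Three measured steps change a group at this carbon. Chloro in place of methyl gave an at least 2.9-fold higher number from compound 1 to compound 2 (0.47 log units; beyond the scatter), and bromo in place of methyl gave an at least 2.9-fold higher number from compound 1 to compound 3 (0.47 log units; beyond the scatter). Bromo in place of chloro gave a step that the two limits leave unreadable from compound 2 to compound 3. Among the measured compounds, only compound 1 at 33500 nM has an exact number, so compound 4 is expected to remain weak in this assay. The expected change is an at least 1.4-fold lower number from compound 2 to compound 4 (0.15 log units; that floor lies within the scatter), a step that will be hard to read against a limit. The estimated value for compound 4 is 70000 nM, with an expected range from 25000 nM to 150000 nM.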

Compound 4, half-maximal inhibitory concentration: > 100000 nM
Compound 4 ended at the assay's limit (the forecaster's own chance of this, stated with the estimate: 55%); middle value at least 1.4-fold (0.15 log units) away from the limit.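

Replacing methyl with nitro gives an at least 2.9-fold higher number from compound 1 to compound 4 (0.47 log units; beyond the scatter), so in this assay a third replacement of the methyl group at this carbon also fails to give an exact number, and this one is not a halogen but a larger group with hydrogen-bond acceptors. The steps among compound 2, compound 3 and compound 4 cannot be read, as each pair compares two limits of the assay and not two numbers. Methyl in compound 1 therefore remains the only group shown here with an exact value, and the other three compounds share one limit: the limit of > 100000 nM in this assay, at which 3 of the 4 values shown sit.

From the compounds shown here alone, how far compound 2, compound 3 and compound 4 lie from one another remains open. So does whether an ethyl group, an amine or a carboxylic acid at this carbon would match or improve on methyl.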